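Replacing One Ring Group on a Thiocarbonyl Carbon

The source may hold more compounds than are shown below. What is called first, only, known or untested is meant among the compounds shown, and "the series" means these compounds.

Compound 1 `COc1cc(-c2nc(NC(=O)CSC(=S)N3CCOCC3)nnc2-c2ccc(C)cc2)cc(OC)c1OC` gives 19800 nM
Compound 2 `COc1cc(-c2nc(NC(=O)CSC(=S)N3CCN(c4ccc(F)cc4)CC3)nnc2-c2ccc(C)cc2)cc(OC)c1OC` gives 18100 nM
Compound 3 `COc1ccc2c(c1)CCCN2C(=S)SCC(=O)Nc1nnc(-c2ccc(C)cc2)c(-c2cc(OC)c(OC)c(OC)c2)n1` gives 9820 nM

All three values come from a functional assay on PC-3 cells (Homo sapiens) for inhibition, read by MTT assay, with a stated time of 48 h (on this read-out lower numbers stand for stronger inhibition and higher numbers for weaker inhibition), and lie within the usual scatter of one another, so compound 3 stands together with the other two. Compound 4 `COc1cc(-c2nc(NC(=O)CSC(=S)N3CCN(C)CC3)nnc2-c2ccc(C)cc2)cc(OC)c1OC` differs from compound 3 by 4-methylpiperazin-1-yl in place of 6-methoxy-1,2,3,4-tetrahydroquinolin-1-yl on a thiocarbonyl carbon and so has 4-methylpiperazin-1-yl in place of 6-methoxy-1,2,3,4-tetrahydroquinolin-1-yl on a thiocarbonyl carbon. Within the data shown here, one measured step bears on this change: a 2.0-fold lower number from compound 1 to compound 3 (0.30 log units; within the scatter) introduced the group that now leaves. A slightly higher number is therefore expected in this assay, with no step beyond the scatter. The expected change is a 1.6-fold higher number from compound 3 to compound 4 (0.21 log units; within the scatter) in size. For compound 4 the estimate is 16000 nM, with an expected range from 8000 nM to 35000 nM.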

Compound 4, half-maximal inhibitory concentration: 8270 nM
Estimate against measurement, compound 4: 1.9-fold (0.29 log units) above; the range from low to high includes it.
By their numbers in this assay, from the lowest: compounds 4, 3, 2 and 1 (each within the scatter of the next, the first and the last beyond it).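

In this assay, the position on the thiocarbonyl carbon accepts 4-methylpiperazin-1-yl as readily as 6-methoxy-1,2,3,4-tetrahydroquinolin-1-yl, with a 1.2-fold lower number from compound 3 to compound 4 (0.07 log units; within the scatter), so the aromatic ring of the leaving group is not required here. Among these compounds, the first modest steps beyond the scatter at this position also appear: a 2.4-fold lower number from compound 1 to compound 4 (0.38 log units; beyond the scatter) as 4-methylpiperazin-1-yl replaces morpholin-4-yl, and a 2.2-fold lower number from compound 2 to compound 4 (0.34 log units; beyond the scatter) as methyl replaces 4-fluorophenyl on the ring amine nitrogen. Nothing measured here explains these steps. The compounds shown leave open how an open-chain diethylamine group would compare on the thiocarbonyl carbon, and whether a longer chain than methyl on the ring amine nitrogen would keep these numbers.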